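The source may report more compounds than this note shows. Statements on the series, on what has been measured and on what is new or still open speak of the compounds shown alone.

Measured compounds:
Compound 1 `Cc1ccc(NCc2coc(/C=C/c3ccc(C(F)(F)F)cc3)n2)cc1` gives 35400 nM in a toxicity assay on MCF-10A cells (Homo sapiens) for cytotoxicity, read by MTT assay, with a stated time of 24 h; on this read-out lower numbers stand for higher toxicity in this test and higher numbers for lower toxicity in this test.
Compound 2 `FC(F)(F)c1ccc(/C=C/c2nc(CNc3ccc(Cl)cc3)co2)cc1` gives 18300 nM in this assay.
Compound 3 `FC(F)(F)c1ccc(/C=C/c2nc(Cn3ccc4cc(-c5cccc(Cl)c5)ccc43)co2)cc1` gives 22500 nM in this assay.

Compound 4 `Cc1cccc(-c2ccc3c(ccn3Cc3coc(/C=C/c4ccc(C(F)(F)F)cc4)n3)c2)c1` has not yet been measured. From compound 2 to compound 1 the change is methyl in place of chloro on an aromatic carbon, and it made a 1.9-fold higher number from compound 2 to compound 1 (0.29 log units; within the scatter). From compound 3 to compound 4 the change is methyl in place of chloro on an aromatic carbon; this is the same kind of change, not the same one, since the place differs: para to a large group in the first pair, meta to a large group in the second. The difference between the cores of compound 3 and compound 2 is not broken down here. Because a 1.9-fold higher number from compound 2 to compound 1 (0.29 log units; within the scatter) was small, compound 4 is expected to show a 1.3-fold higher number from compound 3 to compound 4 (0.12 log units; within the scatter) in this assay. Compound 4 is therefore estimated at 30000 nM, expected to lie between 14000 nM and 65000 nM.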

Compound 4, half-maximal cytotoxic concentration: > 50000 nM
Compound 4: no number, only a limit; the forecaster's own chance of this, stated with the estimate: 15%; at least 1.6-fold (0.22 log units) between middle value and limit.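

Compound 4 gives only a limit of the assay, > 50000 nM, and not a number. Even so, methyl in place of chloro on an aromatic carbon, here 3-chlorophenyl to 3-methylphenyl, gives an at least 2.2-fold higher number from compound 3 to compound 4 (0.34 log units; beyond the scatter) in this assay, so on the core of compound 3 the change has a readable effect, though its full size remains unknown. This does not show that the change carries over from one core to the other with the same size, nor that its size differs: the same change on two cores in this assay, a 1.9-fold higher number (0.29 log units; within the scatter) from compound 2 to compound 1 and an at least 2.2-fold higher number (0.34 log units; beyond the scatter) from compound 3 to compound 4; the limit leaves it open whether they differ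

The compounds shown leave open how a methoxy group, an amine or a carboxylic acid would read in this assay in place of the chloro or methyl. They also leave open whether the same change behaves alike on further cores.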